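This account rests on a few compounds, and the source may have more. Where it says the series, first, only, none or still open, it means among the compounds named here.

Compound 1 `O=C(c1ccccc1)N1CCC(NS(=O)(=O)c2cc(S(=O)(=O)c3ccccc3)ccc2C(F)(F)F)CC1` was tested in an assay on U2OS cells for inhibition of secreted frizzled-related protein 1 (Homo sapiens), read by a luciferase reporter, with a stated time of 18 h (on this read-out higher numbers stand for an effect only at larger amounts of compound and lower numbers for an effect already at smaller amounts), and gave 250 nM. Two close relatives were measured alongside it: compound 2 `CC(C)(C)OC(=O)N1CCC(C(=O)N2CCC(NS(=O)(=O)c3cc(S(=O)(=O)c4ccccc4)ccc3C(F)(F)F)CC2)CC1` gave 420 nM, and compound 3 `CC(C)(C)OC(=O)N1CCC(CC(=O)N2CCC(NS(=O)(=O)c3cc(S(=O)(=O)c4ccccc4)ccc3C(F)(F)F)CC2)CC1` gave 400 nM. The number for compound 1 is the smallest of the three, yet the numbers of compound 2 and compound 3 both lie within the usual scatter of it, so the three compounds cannot be told apart on this evidence.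

Compound 4 `CC(C)(C)OC(=O)N1CC[C@H](C(=O)N2CCC(NS(=O)(=O)c3cc(S(=O)(=O)c4ccccc4)ccc3C(F)(F)F)CC2)C1` has not yet been measured. It differs from compound 1 in one place: 1-(tert-butoxycarbonyl)pyrrolidin-3-yl in place of phenyl on a carbonyl carbon. Among the measured compounds shown here, no measured pair shows this exact change, so its effect can only be guessed from the fact that the two relatives bearing a related saturated ring in place of the phenyl, compound 2 and compound 3, sit close to compound 1. The step from compound 1 to compound 4 is expected to be small, probably a slight rise that stays within the scatter, as a 1.6-fold higher number from compound 1 to compound 4 (0.20 log units; within the scatter) expresses. On that basis compound 4 is estimated to give 400 nM in this assay, with a likely range from 200 nM to 900 nM.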

Compound 4, half-maximal effective concentration: 150 nM
The estimate for compound 4 lay 2.7-fold (0.43 log units) above the measured number; the whole stated range lies above it.
By their numbers in this assay, from the lowest: compounds 4, 1, 3 and 2 (each within the scatter of the next, the first and the last beyond it).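

In this assay, placing 1-(tert-butoxycarbonyl)pyrrolidin-3-yl instead of phenyl on the carbonyl carbon gives a 1.7-fold lower number from compound 1 to compound 4 (0.22 log units; within the scatter) and so cannot be called a real gain. The point lies in how much changes while the number stays within the scatter: an aromatic carbon ring of 6 heavy atoms with no hydrogen-bond acceptors gives way to a non-aromatic five-membered ring group of 12 heavy atoms with 2 acceptors and one defined stereocentre. This position therefore accepts a far larger and different group in this assay, although no measurement here explains why.

As far as these compounds go, the effect of the mirror-image form of compound 4 remains open. So does what a free amine would do on the pyrrolidine ring in place of the tert-butoxycarbonyl group.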